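This account rests on a few compounds, and the source may have more. Where it says the series, first, only, none or still open, it means among the compounds named here.

Going by the values given here, compound 1, whose structure is `CC1CCN(S(=O)(=O)N2CCN(CC(=O)Nc3cccc(F)c3)CC2)CC1`, is the one member of this small set that returned an actual number. In an assay on HEK293 cells for activation of potassium channel subfamily T member 1 (Homo sapiens), read by thallium flux (on this read-out higher numbers stand for an effect only at larger amounts of compound and lower numbers for an effect already at smaller amounts), compound 1 gives 4600 nM. Compound 2, drawn as `COc1ccc(Cl)cc1NC(=O)CN1CCN(S(=O)(=O)N2CCN(C(=O)N3CCCCC3)CC2)CC1`, keeps the sulfonyl-linked core but carries a different group at the far end, and compound 2 reaches only the limit > 10000 nM, which is a boundary of the assay rather than a measured number. Compound 3, with structure `COc1ccc(Cl)cc1NC(=O)N1CC2(CCN(S(=O)(=O)N3CCC(C)CC3)CC2)C1`, is built around a more rigid core, and compound 3 likewise stops at the limit > 10000 nM. Compound 1 therefore stands alone with a value, since the two other results sit at the limit of > 10000 nM in this assay, at which 2 of the 3 values shown sit.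

Compound 4 is `CC1CCN(S(=O)(=O)N2CCN(CC(=O)Nc3ccccc3)CC2)CC1`. It differs from compound 1 by hydrogen in place of fluoro on an aromatic carbon, meta to a large group. Among the compounds with values here, a single fluorine removed from a ring is a small change, and nothing among the measured compounds points to it in either direction. The expected shift in this assay from compound 1 to compound 4 is therefore modest, a slight loss of potency that may well sit within the usual scatter, giving a 1.4-fold higher number from compound 1 to compound 4 (0.15 log units; within the scatter). On that basis compound 4 is estimated at 6500 nM, within a range from 2500 nM to 16000 nM.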

Compound 4, half-maximal effective concentration: > 10000 nM
Compound 4: a limit, no number; the forecaster's own chance of this, stated with the estimate: 25%; middle value at least 1.5-fold (0.18 log units) away from the limit.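

Going by these compounds alone, until now, no two measured compounds differed in only one place, so nothing showed what a single group on the core of compound 1 contributes. This pair gives that first view: with hydrogen in place of fluoro on an aromatic carbon, meta to a large group, this assay shows an at least 2.1-fold higher number from compound 1 to compound 4 (0.33 log units; beyond the scatter), so this one fluorine atom makes a difference that can be told apart from ordinary assay scatter. The result for compound 4 is a limit and not a number, so the full size of the step stays unknown, and compound 4 joins the compounds without a measured value: the limit of > 10000 nM in this assay, at which 3 of the 4 values shown sit.

The compounds shown leave open whether fluoro is special at this carbon or whether another group there, such as nitrile or trifluoromethyl, would serve as well, and whether fluoro elsewhere on the ring would have the same effect. On these data alone, whether any such group would give a lower number than compound 1, at 4600 nM, also remains open.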